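The source may report more compounds than this note shows. Statements on the series, on what has been measured and on what is new or still open speak of the compounds shown alone.

Working notes on the series. Three compounds share a chlorophenyl-piperazine motif with varying heteroaryl heads: compound 1 `Nc1ncnc(N2CCN(c3cccc(Cl)c3)CC2)c1[N+](=O)[O-]`, compound 2 `Clc1cccc(N2CCN(c3ncnc4[nH]ccc34)CC2)c1` and compound 3 `Clc1cccc(N2CCN(c3ncnc4[nH]ncc34)CC2)c1`. In an assay for inhibition of ribosomal protein S6 kinase beta-1 variant D18H,T412E (Homo sapiens), read by a luciferase reporter and chemiluminescence, with a stated time of 3 h (on this read-out higher numbers stand for weaker inhibition and lower numbers for stronger inhibition), compound 1 gives 85 nM, compound 2 gives 162 nM and compound 3 gives 107 nM. Compound 3 lies within the scatter of both compound 1 and compound 2, so the three numbers show no separation on this assay.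

Compound 4 `Cc1ccc(Cl)cc1N1CCN(c2ncnc3[nH]ncc23)CC1` carries the change methyl in place of hydrogen on an aromatic carbon relative to compound 3, a methyl in place of hydrogen on an aromatic carbon. Within the data shown here, no comparable step has been measured here, so no direction is documented. The expected step from compound 3 to compound 4 on this assay is a 1.2-fold higher number from compound 3 to compound 4 (0.08 log units; within the scatter), taken as not beyond the scatter. Compound 4 is estimated at 130 nM, with a range from 50 nM to 350 nM.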

Compound 4, half-maximal inhibitory concentration: 13 nM
For compound 4 the middle estimate is 10-fold (1.00 log units) above the measured one; the whole stated range lies above it.
By their numbers in this assay, from the lowest: compound 4; then compounds 1, 3 and 2 (each within the scatter of the next).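

In this assay, among these compounds, methyl in place of hydrogen on an aromatic carbon, ortho to a large group and para to a chloro group, gives an 8.2-fold lower number from compound 3 to compound 4 (0.92 log units; beyond the scatter), the first step that lies beyond the scatter. Among the compounds shown here, this position therefore responds strongly to the addition of a single carbon, which the earlier compounds, differing only in their heteroaryl heads, did not reveal. Nothing available here accounts for the size of this step.

From the compounds shown here alone, whether the effect is specific to methyl stays open, as an ethyl, a methoxy or a fluoro group at this position would show. Also open, going by these compounds, is whether the same methyl has a similar effect on the cores of compound 1 and compound 2.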